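The compounds below may be only part of what the source reports. "The series", "measured", "known", "first", "only" and "open" are said of these compounds alone.

Three compounds have been measured in a functional assay on HOP-62 cells (Homo sapiens) for cytotoxicity, read by sulforhodamine B assay, with a stated time of 48 h; on this read-out higher numbers stand for weaker inhibition of growth and lower numbers for stronger inhibition of growth:

Compound 1 `ClCc1ccccc1Cn1cnc2c(Cl)nc(Cl)nc21`: 2040 nM
Compound 2 `ClCc1ccccc1Cn1cnc2c(Cl)ncnc21`: 2510 nM
Compound 3 `ClCc1cccc(Cn2cnc3ncnc(Cl)c32)c1`: 2180 nM

Compound 2 has the highest of these three numbers, yet its gaps to compound 3 and to compound 1 lie within the scatter, so the three stand level. Compound 4 `Nc1nc(Cl)c2ncn(Cc3ccccc3CCl)c2n1` differs from compound 2 by amino in place of hydrogen on an aromatic carbon. Going by the values given here, the only measured step that bears on this, a 1.2-fold higher number from compound 1 to compound 2 (0.09 log units; within the scatter), also swaps a substituent on an aromatic carbon of the shared core and stayed within the scatter. Among the compounds with values here, no measured step adds a hydrogen-bond donor or acceptor, so the amino group itself is untested here. The expected step is therefore a 1.0-fold lower number from compound 2 to compound 4 (0.00 log units; within the scatter). In this assay compound 4 is estimated at 2500 nM, with a range from 1000 nM to 6500 nM.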

Compound 4, concentration for 50% growth inhibition: 21900 nM
Estimate against measurement, compound 4: 8.8-fold (0.94 log units) below, and the stated range ends below it.
By their numbers in this assay, from the lowest: compounds 1, 3 and 2 (each within the scatter of the next); then compound 4.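

In this assay, the aromatic carbon between two ring nitrogen atoms turns out not to accept every group equally: amino in place of hydrogen gives (an 8.7-fold higher number from compound 2 to compound 4 (0.94 log units; beyond the scatter)), and amino in place of chloro gives (an 11-fold higher number from compound 1 to compound 4 (1.03 log units; beyond the scatter)). Hydrogen and chloro stood level here, so amino is the first group at this place to weaken growth inhibition beyond the scatter. Nothing measured here explains this loss. From the compounds shown here alone, whether a methylamino or hydroxyl group would behave like amino remains open. So does whether amino would have the same effect on compound 3.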